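Ester variation on a shared core: cytotoxicity notes

This account rests on a few compounds, and the source may have more. Where it says the series, first, only, none or still open, it means among the compounds named here.

Compound 1 `CC(=O)OCCc1c(-c2ccccc2Cl)c2cc(Cl)ccc2[nH]c1=O` gives 27000 nM in an ADME assay on HepG2 2.2.15 cells (Homo sapiens) for cytotoxicity (on this read-out higher numbers stand for lower toxicity in this test and lower numbers for higher toxicity in this test), and compound 2 `COCC(=O)OCCc1c(-c2ccccc2Cl)c2cc(Cl)ccc2[nH]c1=O` gives 74000 nM, a step of a 2.7-fold higher number from compound 1 to compound 2 (0.44 log units; beyond the scatter). Compound 3 `CC12CCC(C(=O)OCCc3c(-c4ccccc4Cl)c4cc(Cl)ccc4[nH]c3=O)(OC1=O)C2(C)C` reaches only the assay limit, recorded as > 1800000 nM, so it stands at the top of the series (the limit of > 1800000 nM in this assay, at which 1 of the 3 values shown sits). The steps of an at least 66-fold higher number from compound 1 to compound 3 (1.82 log units; beyond the scatter) and an at least 24-fold higher number from compound 2 to compound 3 (1.38 log units; beyond the scatter) show that the bulkier ester gave much higher numbers than the small esters. Compound 4 `COc1cccc(/C=C/C(=O)OCCc2c(-c3ccccc3Cl)c3cc(Cl)ccc3[nH]c2=O)c1` carries a group of 10 heavy atoms (9 carbon, 1 oxygen; one six-membered aromatic ring of carbon only) in place of a group of 11 heavy atoms (9 carbon, 2 oxygen; one five-membered non-aromatic ring of carbon only, one five-membered non-aromatic ring with 1 hetero atom), on a carbonyl carbon. For the measured compounds named here, no measured step covers this exact exchange; both neighbours of compound 3 are small esters, so the direction from compound 3 is uncertain. Compound 4 is expected near 300000 nM, within 60000 nM to 1800000 nM, an estimated step of an at least 6.0-fold lower number from compound 3 to compound 4 (0.77 log units; beyond the scatter).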

Compound 4, half-maximal cytotoxic concentration: > 1300000 nM
Compound 4 was reported as a limit; the forecaster's own chance of this, stated with the estimate: 35%; middle value at least 4.3-fold (0.63 log units) from the limit.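

On the carbonyl carbon, 2-(3-methoxyphenyl)ethenyl also raises the number well past the small esters in this assay: an at least 17-fold higher number from compound 2 to compound 4 (1.24 log units; beyond the scatter) and an at least 48-fold higher number from compound 1 to compound 4 (1.68 log units; beyond the scatter). High numbers at this position therefore do not require the two saturated five-membered rings of compound 3, since compound 4 carries one six-membered aromatic ring of carbon only in their place. The step from compound 3 to compound 4 cannot be read, as compound 4 is also reported only as a limit: the limit of > 1300000 nM in this assay, at which 1 of the 4 values shown sits.

Still open, on these data alone, is how compound 3 and compound 4 rank. Also open, as far as these compounds go, is whether a plain longer alkyl chain or a carboxylic acid on this carbonyl carbon would keep the numbers this high.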